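Thiophene carboxamide series: thiourea aryl swap, antiproliferative read-out

This account rests on a few compounds, and the source may have more. Where it says the series, first, only, none or still open, it means among the compounds named here.

Measured compounds:
compound 1 `NC(=O)c1c(NC(=O)c2ccccc2Cl)sc2c1CCN(Cc1ccc(Cl)cc1Cl)C2`, 16300 nM
compound 2 `NC(=O)c1c(NC(=O)c2ccccc2Cl)sc2c1CCN(C(=O)Nc1ccccc1Cl)C2`, 16300 nM
compound 3 `COc1ccccc1NC(=S)N1CCc2c(sc(NC(=O)c3ccccc3Cl)c2C(N)=O)C1`, 35200 nM

In a functional assay on MKN-74 cells (Homo sapiens) for antiproliferative activity, with a stated time of 24 h (on this read-out higher numbers stand for weaker inhibition and lower numbers for stronger inhibition), compound 3 gives the highest of the three numbers, beyond the scatter from both others: a 2.2-fold higher number from compound 1 to compound 3 (0.33 log units; beyond the scatter) and a 2.2-fold higher number from compound 2 to compound 3 (0.33 log units; beyond the scatter). The change from compound 1 to compound 2 is no change at the digits printed from compound 1 to compound 2 (within the scatter).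

Compound 4 `NC(=O)c1c(NC(=O)c2ccccc2Cl)sc2c1CCN(C(=S)Nc1c(Cl)cccc1Cl)C2` differs from compound 3 by 2,6-dichlorophenyl in place of 2-methoxyphenyl on an amide-type nitrogen. For the measured compounds named here, no measured pair isolates an aryl swap on the thiocarbonyl nitrogen, so the bearing steps are only the modest shifts between compounds 1, 2 and 3. A step no larger than those is expected: a 1.6-fold lower number from compound 3 to compound 4 (0.20 log units; within the scatter). Compound 4 is estimated at 22000 nM, range 9000 nM to 55000 nM.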

Compound 4, half-maximal inhibitory concentration: 4020 nM
Beside the measured number, compound 4's estimate is 5.5-fold (0.74 log units) above it; the measured number lies below the stated range.
By their numbers in this assay, from the lowest: compound 4; then compounds 1 and 2 (each within the scatter of the next); then compound 3.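

In this assay, the aryl group on the amide-type nitrogen whose other neighbour is the thiocarbonyl carbon proves a strong handle, with an 8.8-fold lower number from compound 3 to compound 4 (0.94 log units; beyond the scatter) for 2,6-dichlorophenyl in place of 2-methoxyphenyl. The thiocarbonyl alone does not set the number, since compound 3 and compound 4 both carry it yet stand highest and lowest. Compound 4 also improves on the other two groups on the ring nitrogen, with a 4.1-fold lower number from compound 2 to compound 4 (0.61 log units; beyond the scatter) and a 4.1-fold lower number from compound 1 to compound 4 (0.61 log units; beyond the scatter) as the steps.

On these data alone, whether the chlorines or the absence of methoxy drive the gain stays open, and 2-methylphenyl or 4-aminophenyl on that nitrogen could help separate them. No supporting data explain the shift.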